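A Methoxy-to-Trifluoromethyl Swap Against Hormone-sensitive Lipase

The source may hold more compounds than are shown below. What is called first, only, known or untested is meant among the compounds shown, and "the series" means these compounds.

Measured so far:
Compound 1 `Cc1c(C(C)C)c(=O)on1C(=O)N1CCC(Cc2ccccc2)CC1` gives 102 nM in an assay (strain Wistar) for inhibition of Hormone-sensitive lipase (Rattus norvegicus), read by spectrophotometry; a higher number here means a weaker inhibitor, a lower number a stronger inhibitor.
Compound 2 `COc1ccc(-c2nc(SC)n(C(=O)N(C)C)n2)cc1` gives 15.9 nM in this assay.

Of the two numbers in this assay, compound 2 stands lowest. Its nearest neighbour is compound 1, whose number is higher by a gap that lies beyond the usual scatter, so the two compounds are clearly separated on this read-out. For the measured compounds named here, the two share no common scaffold, and no pair of measured compounds differs in a single place, so no step of known size is available.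

Compound 3 `CSc1nc(-c2ccc(C(F)(F)F)cc2)nn1C(=O)N(C)C` is the next compound to be measured. It differs from compound 2 in one place: trifluoromethyl in place of methoxy on an aromatic carbon. Going by the values given here, nothing among the measured compounds isolates the effect of this exchange. The reasonable expectation is a small step, with no strong reason for either direction, and a move beyond the scatter cannot be ruled out. Compound 3 is expected to give about 25 nM in this assay, with a range from 6 nM to 100 nM. This estimate corresponds to a step of a 1.6-fold higher number from compound 2 to compound 3 (0.20 log units; within the scatter).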

Compound 3, half-maximal inhibitory concentration: 1.76 nM
Compound 3: the middle estimate sits 14-fold (1.15 log units) above what was measured, and the stated range ends above it.
By their numbers in this assay, from the lowest: compound 3; then compound 2; then compound 1.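

In this assay the exchange of methoxy for trifluoromethyl on an aromatic carbon para to a large group gives a 9.0-fold lower number from compound 2 to compound 3 (0.96 log units; beyond the scatter) and so shows that this position is not indifferent: what sits there can move the read-out by more than repeated measurements would. Methoxy counts as a hydrogen-bond acceptor and trifluoromethyl does not, and trifluoromethyl brings more heavy atoms, but this single pair cannot separate those differences or show whether either one matters. Nothing available bears on why the number falls with this change.

On these data alone, it remains open whether the lower number belongs to trifluoromethyl itself or simply to the absence of methoxy, and a bare hydrogen, a chlorine atom or a nitrile at this position would help to tell those two readings apart. Also open, as far as these compounds go, is whether a step of similar size would appear on a changed core, for example one with an amine in place of the sulfur-linked methyl group.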